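Working notes: pyridin-2-yl in place of pyridin-4-yl

The source may report more compounds than this note shows. Statements on the series, on what has been measured and on what is new or still open speak of the compounds shown alone.

Measured in a physicochemical assay for solubility, measured as kinetic solubility, with a stated time of 1 h, at pH 7.4; a lower number here means a less soluble compound, a higher number a more soluble compound:
- compound 1 (`CC(=O)N[C@@H](C)C(=O)NC1=NN(c2ccc(Cl)c(Cl)c2)CC1`) at 58000 nM
- compound 2 (`O=C(NC1=NN(c2ccc(Cl)c(Cl)c2)CC1)c1ccncc1`) at 9000 nM

Compound 2 at 9000 nM holds the lower of the two numbers. Compound 3 (`O=C(NC1=NN(c2ccc(Cl)c(Cl)c2)CC1)c1ccccn1`) carries pyridin-2-yl in place of pyridin-4-yl on a carbonyl carbon. Among the measured compounds shown here, the only measured step, a modest one (a 6.4-fold lower number from compound 1 to compound 2 (0.81 log units; beyond the scatter)), exchanged 1-acetamidoethyl for pyridin-4-yl. For the measured compounds named here, no measured pair compares two pyridinyl groups, so that step bears only loosely on this change. In this assay no step beyond the scatter is expected, and the expected step (a 1.3-fold lower number from compound 2 to compound 3 (0.11 log units; within the scatter)) leans slightly lower. The estimate for compound 3 is 7000 nM (expected range 2500 nM to 20000 nM).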

Compound 3, solubility: 11000 nM
Compound 3: the middle estimate sits 1.6-fold (0.20 log units) below what was measured; the range from low to high includes it.
By their numbers in this assay, from the lowest: compounds 2 and 3 (each within the scatter of the next); then compound 1.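

In this assay, pyridin-2-yl in place of pyridin-4-yl on a carbonyl carbon gives a 1.2-fold higher number from compound 2 to compound 3 (0.09 log units; within the scatter), so the two pyridinyl groups are not told apart at this position. Pyridin-2-yl in place of 1-acetamidoethyl gives a 5.3-fold lower number from compound 1 to compound 3 (0.72 log units; beyond the scatter), so the step away from 1-acetamidoethyl is beyond the scatter with either pyridinyl group. No measurement on hand offers an explanation for these steps.

As far as these compounds go, whether pyridin-3-yl or phenyl on the same carbonyl carbon would stay within the scatter of compound 2 and compound 3 remains open. So does the outcome for a pyridinyl group carrying an amine or a carboxylic acid.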